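Swapping the Aryl Group at the End of the Chain

A few compounds are considered here, and "the series" means these few. Any claim that something is new, unique, unknown or untested is made for them only; others in the source may bear on it.

Of the compounds shown here, three built on one shared core have been tested in an ADME assay on the whole organism for cytotoxicity, with Artemia salina as the target, with a stated time of 24 h; on this read-out lower numbers stand for an effect already at smaller amounts and higher numbers for an effect only at larger amounts of compound. Compound 1 `Cc1ccc(/C=C/C(=O)c2ccccc2NC(=O)NS(=O)(=O)c2ccc(C)cc2)cc1` gives 15.3 ug/mL, compound 2 `COc1cccc(/C=C/C(=O)c2ccccc2NC(=O)NS(=O)(=O)c2ccc(C)cc2)c1` gives 23.2 ug/mL, and compound 3 `COc1cc(/C=C/C(=O)c2ccccc2NC(=O)NS(=O)(=O)c2ccc(C)cc2)ccc1O` gives 17.8 ug/mL. Compound 2 carries the upper number of the three, yet it is separated from the others by very little: a 1.3-fold lower number from compound 2 to compound 3 (0.12 log units; within the scatter) and a 1.5-fold higher number from compound 1 to compound 2 (0.18 log units; within the scatter). The remaining pair, a 1.2-fold higher number from compound 1 to compound 3 (0.07 log units; within the scatter), also stays within the scatter. Each of these three steps exchanges the aryl group on the double-bonded chain carbon, and none moved the read-out beyond the usual scatter.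

Compound 4 `Cc1ccc(S(=O)(=O)NC(=O)Nc2ccccc2C(=O)/C=C/c2cc(O)ccc2[N+](=O)[O-])cc1` changes the same place: 5-hydroxy-2-nitrophenyl in place of 3-methoxyphenyl on a double-bonded chain carbon bound to a double-bonded chain carbon. Because a 1.5-fold higher number from compound 1 to compound 2 (0.18 log units; within the scatter), a 1.2-fold higher number from compound 1 to compound 3 (0.07 log units; within the scatter) and a 1.3-fold lower number from compound 2 to compound 3 (0.12 log units; within the scatter) all stayed within the scatter, no step beyond the scatter is expected in this assay for this new exchange either. Compound 4 is therefore estimated at 20 ug/mL, within a range from 8 ug/mL to 50 ug/mL. The expected step is a 1.2-fold lower number from compound 2 to compound 4 (0.06 log units; within the scatter).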

Compound 4, concentration for half-maximal effect: 18.3 ug/mL
Estimate against measurement, compound 4: 1.1-fold (0.04 log units) above; the range from low to high includes it.
By their numbers in this assay, from the lowest: compounds 1, 3, 4 and 2 (each within the scatter of the next).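

For the compounds shown here, the 5-hydroxy-2-nitrophenyl group is the first aryl group in this set to carry a nitro group, and it brings more heavy atoms and more hydrogen-bond acceptors than the 3-methoxyphenyl it replaces, yet in this assay this exchange gives only a small step (a 1.3-fold lower number from compound 2 to compound 4 (0.10 log units; within the scatter)). Against the other two aryl groups the picture is the same, with a 1.0-fold higher number from compound 3 to compound 4 (0.01 log units; within the scatter) and a 1.2-fold higher number from compound 1 to compound 4 (0.08 log units; within the scatter), so the four phenyl groups tested on this double-bonded chain carbon cannot be told apart on this read-out. No measurement at hand explains why this position tolerates such different groups.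

Going by these compounds, all four compounds keep a phenyl ring at this place, so it remains open whether an amine, a carboxylic acid or a longer chain on that ring would shift the number. The shared core is also unchanged throughout, which leaves the effect of changes elsewhere in the molecule unknown.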